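Compound 3 and a Carbonyl Added to Its Chain

The source may hold more compounds than are shown below. What is called first, only, known or untested is meant among the compounds shown, and "the series" means these compounds.

compound 1 `O=C(NNc1ccccc1F)c1ccc(NS(=O)(=O)c2cnc(O)nc2O)cc1` gives > 20000 nM (a limit, not a number)
compound 2 `O=C(NNc1cccc(Cl)c1)c1cccc(NS(=O)(=O)c2cnc(O)nc2O)c1` gives 7760 nM
compound 3 `O=C(NNc1cccc(Cl)c1)c1ccccc1NS(=O)(=O)c1cnc(O)nc1O` gives 11800 nM

In a functional assay on MDA-MB-231 cells (Homo sapiens) for antiproliferative activity, read by MTT assay, with a stated time of 24 h (on this read-out higher numbers stand for weaker inhibition and lower numbers for stronger inhibition), compound 3 gives 11800 nM and so lies within the usual scatter of compound 2 (7760 nM). Compound 4 `O=C(NNC(=O)c1ccccc1NS(=O)(=O)c1cnc(O)nc1O)c1cccc(Cl)c1` carries (3-chlorophenyl)carbonyl in place of 3-chlorophenyl on an amine nitrogen. Going by the values given here, no measured pair shows this change, so the expectation rests on compound 3 alone (11800 nM), and no step beyond the scatter is expected in this assay. The estimated step of a 1.2-fold higher number from compound 3 to compound 4 (0.07 log units; within the scatter) is therefore expected to be small, though the range stays wide. For compound 4 the estimate is 14000 nM with 5000 nM to 40000 nM as its expected range.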

Compound 4, half-maximal inhibitory concentration: 4420 nM
Compound 4: the middle estimate sits 3.2-fold (0.50 log units) above what was measured; the whole stated range lies above it.
By their numbers in this assay, from the lowest: compounds 4, 2 and 3 (each within the scatter of the next, the first and the last beyond it). At a limit, above all of these: compound 1.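

In this assay, replacing 3-chlorophenyl with (3-chlorophenyl)carbonyl on the amine nitrogen gives a 2.7-fold lower number from compound 3 to compound 4 (0.43 log units; beyond the scatter). This single change is enough to move the number beyond the usual scatter, so this part of the chain can affect activity in these cells. The data shown give no cause for the step. Going by these compounds, it stays open whether the carbonyl itself matters or simply the longer chain. A sulfonyl or a methylene group in the carbonyl's place would help separate these two readings.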